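The source may hold more compounds than are shown below. What is called first, only, known or untested is meant among the compounds shown, and "the series" means these compounds.

Three compounds share one core and differ only in the aryl group at the end of the propoxy chain. Compound 1 `NC1=NC2(CCSCC2)N(OCCCOc2cccc(Cl)c2Cl)C(N)=N1` gives 1 nM in a functional assay on HCT-116 cells (Homo sapiens) for antiproliferative activity, read by MTT assay, with a stated time of 72 h; a higher number here means a weaker inhibitor, a lower number a stronger inhibitor; compound 2 `NC1=NC2(CCSCC2)N(OCCCOc2ccc(Br)cc2)C(N)=N1` gives 20 nM; compound 3 `NC1=NC2(CCSCC2)N(OCCCOc2cc(Cl)c(Cl)cc2Cl)C(N)=N1` gives 1 nM, level with compound 1 and together with it the lowest of the three numbers. Compound 4 `NC1=NC2(CCSCC2)N(OCCCOc2ccc(Cl)c(Cl)c2)C(N)=N1` carries the change (hydrogen in place of chloro on an aromatic carbon). Within the data shown here, two measured steps bear on this: no change at the digits printed from compound 1 to compound 3 (within the scatter), and a 20-fold lower number from compound 2 to compound 3 (1.30 log units; beyond the scatter). Adding a third chloro to a dichlorophenyl therefore changed nothing, while going from a single halogen to three made a large difference, so a dichlorophenyl is expected to sit close to compound 3. Compound 4 is therefore expected to give 2 nM, within 0.5 nM to 8 nM, a step of a 2.0-fold higher number from compound 3 to compound 4 (0.30 log units; within the scatter) that is expected to stay within the scatter.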

Compound 4, half-maximal inhibitory concentration: 1 nM
Estimate against measurement, compound 4: 2.0-fold (0.30 log units) above; the measured number falls inside the stated range.
By their numbers in this assay, from the lowest: compounds 1, 3 and 4 (each within the scatter of the next); then compound 2.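

In this assay, hydrogen in place of the chloro on this aromatic carbon gives no change at the digits printed from compound 3 to compound 4 (within the scatter), so the low number does not depend on this chloro. Moving from 2,3-dichlorophenyl to 3,4-dichlorophenyl gives no change at the digits printed from compound 1 to compound 4 (within the scatter), so these two chloro patterns read alike, while 3,4-dichlorophenyl in place of 4-bromophenyl gives a 20-fold lower number from compound 2 to compound 4 (1.30 log units; beyond the scatter). Nothing measured here explains these results. The compounds shown leave open whether a phenyl carrying one chloro would keep the low number, and whether a methoxy group or an amine could stand in place of the chloro groups.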